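The source may report more compounds than this note shows. Statements on the series, on what has been measured and on what is new or still open speak of the compounds shown alone.

Among the compounds with values here, compound 1 `COc1cc(N2C(N)=C(C#N)C(c3ccc([N+](=O)[O-])cc3)C3=C2CC(C)(C)CC3=O)cc(OC)c1OC` gives 80% in a functional assay on Ehrlich cells (Mus musculus) for cytotoxicity, tested at 100 ug/mL (a higher number here means a stronger effect of the compound at the concentration tested, a lower number a weaker effect), the higher of the two measured numbers; compound 2 `COc1ccc(C2C(C#N)=C(N)N(c3cc(OC)c(OC)c(OC)c3)C3=C2C(=O)CC(C)(C)C3)cc1` gives 15%, and the only measured step, a number 65 percentage points lower from compound 1 to compound 2 (beyond the scatter), came with methoxy in place of nitro on an aromatic carbon. Compound 3 `COc1cc(N2C(N)=C(C#N)C(c3ccccc3O)C3=C2CC(C)(C)CC3=O)cc(OC)c1OC` differs from compound 1 by 2-hydroxyphenyl in place of 4-nitrophenyl on a saturated ring carbon. The change is not the same as the measured one, but it also removes the nitro group, so a drop in this assay is expected, though of uncertain size. Compound 3 is therefore estimated at 35%, between 10% and 70%, a step of a number 45 percentage points lower from compound 1 to compound 3 (beyond the scatter).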

Compound 3, a percentage reported as activity, at one concentration (the size of the read-out at that concentration, not a potency): 10%
Compound 3: middle estimate off by 25 percentage points, on the high side; measured number inside the range.
By their numbers in this assay, from the lowest: compounds 3 and 2 (each within the scatter of the next); then compound 1.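

In this assay, the second replacement of 4-nitrophenyl on the saturated ring carbon also brings a large loss, with a number 70 percentage points lower from compound 1 to compound 3 (beyond the scatter). Among the compounds shown, compound 1 is therefore the only one with a high number, and it is also the only one carrying a nitro group. Replacing 4-methoxyphenyl with 2-hydroxyphenyl gives a number 5 percentage points lower from compound 2 to compound 3 (within the scatter), so these two groups cannot be told apart here. No evidence bears on the reason for this result. The compounds shown leave open whether a trifluoromethyl group or an amine on this phenyl ring would retain the number of compound 1.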